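Swapping azido for a phenyl triazole on the chain

The compounds below may be only part of what the source reports. "The series", "measured", "known", "first", "only" and "open" are said of these compounds alone.

Values in a functional assay on SW480 cells (Homo sapiens) for antiproliferative activity, read by MTT assay, with a stated time of 48 h; a lower number here means a stronger inhibitor, a higher number a weaker inhibitor
compound 1 `CCCCCCCCC[C@H](CCO)n1cnc2c(Cl)ncnc21` gives 1630 nM
compound 2 `CCCCCCCCC[C@H](CCOS(C)(=O)=O)n1cnc2c(Cl)ncnc21` gives 9720 nM
compound 3 `CCCCCCCCC[C@H](CCN=[N+]=[N-])n1cnc2c(Cl)ncnc21` gives 1220 nM

Among these three numbers, compound 3 holds a shared place. Its nearest neighbour cannot be separated from it (a 1.3-fold lower number from compound 1 to compound 3 (0.13 log units; within the scatter)), whereas the remaining compound lies clearly off (an 8.0-fold lower number from compound 2 to compound 3 (0.90 log units; beyond the scatter)).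

Compound 4 (`CCCCCCCCC[C@H](CCn1cc(-c2ccccc2)nn1)n1cnc2c(Cl)ncnc21`) carries 4-phenyl-1H-1,2,3-triazol-1-yl in place of azido on a saturated chain carbon, three bonds along the chain from an aromatic nitrogen. Only the changes at this same place bear on it. Azido in place of hydroxy moved the number no further than the scatter (a 1.3-fold lower number from compound 1 to compound 3 (0.13 log units; within the scatter)), while adding methylsulfonyl on the oxygen gave a modest rise (a 6.0-fold higher number from compound 1 to compound 2 (0.78 log units; beyond the scatter)). Within the data shown here, no measured compound has a ring at this place, so the size of the coming step is poorly fixed. Going by compound 2 (a 6.0-fold higher number from compound 1 to compound 2 (0.78 log units; beyond the scatter)), the only measured change from compound 1 that went beyond the scatter, a modest rise is expected rather than a fall. The expected step is small to modest (a 2.5-fold higher number from compound 3 to compound 4 (0.39 log units; beyond the scatter)). For compound 4 the estimated value is 3000 nM, with an expected range from 800 nM to 11000 nM in this assay.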

Compound 4, half-maximal inhibitory concentration: 8570 nM
For compound 4 the middle estimate is 2.9-fold (0.46 log units) below the measured one; low and high end bracket the measured number.
By their numbers in this assay, from the lowest: compounds 3 and 1 (each within the scatter of the next); then compounds 4 and 2 (each within the scatter of the next).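

In this assay, the step from azido to 4-phenyl-1H-1,2,3-triazol-1-yl (a 7.0-fold higher number from compound 3 to compound 4 (0.85 log units; beyond the scatter)) shows that this place on the saturated chain does not accept every group equally, although the earlier swap of hydroxy for azido had left the number within the scatter; the same ring-bearing group also stands clearly off the hydroxy compound (a 5.3-fold higher number from compound 1 to compound 4 (0.72 log units; beyond the scatter)). The triazole cannot be separated from the (methylsulfonyl)oxy group (a 1.1-fold lower number from compound 2 to compound 4 (0.05 log units; within the scatter)), so a group with two aromatic rings and one with none end up at the same level, and the four compounds fall into two pairs, compounds 1 and 3 on the lower side and compounds 2 and 4 on the higher. The data offer no measured reason for this split into two levels.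

With a single ring-bearing group at this place, the compounds shown leave open whether the higher number goes with the triazole itself or with its phenyl group, which an unsubstituted triazole or a triazole bearing a hydroxymethyl group would help to separate. They also leave open how a primary amine or a carboxylic acid at the same place would compare with hydroxy and azido.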